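The compounds below may be only part of what the source reports. "The series", "measured", "known", "first", "only" and "open" are said of these compounds alone.

In a physicochemical assay for lipophilicity, read by mass spectrometry (on this read-out lower numbers stand for lower lipophilicity and higher numbers for higher lipophilicity), compound 3 `COc1cc2c(cc1OC)C(=O)C(C(=O)Nc1ccc(Cl)cc1)C2` gives 2.76, second highest of three numbers. Compound 1 `CCc1ccc(NC(=O)C2Cc3cc(OC)c(OC)cc3C2=O)cc1` gives 3.11 and compound 2 `COc1ccc(NC(=O)C2Cc3cc(OC)c(OC)cc3C2=O)cc1` gives 2.08. Compound 4 `CCc1cccc(NC(=O)C2Cc3cc(OC)c(OC)cc3C2=O)c1` is next, with 3-ethylphenyl in place of 4-chlorophenyl on an amide-type nitrogen. The closest measured change, chloro in place of ethyl on an aromatic carbon, is a modest step, a number 0.35 log units lower from compound 1 to compound 3 (beyond the scatter). Read in reverse, it points upward for the ethyl-bearing compound 4. The large step of a number 1.03 log units lower from compound 1 to compound 2 (beyond the scatter) and the modest step of a number 0.68 log units higher from compound 2 to compound 3 (beyond the scatter) both involve methoxy, which is absent from compound 4. Among the compounds with values here, no measured compound carries 3-ethylphenyl itself, so only a modest rise in this assay is expected. The expected step is a number 0.29 log units higher from compound 3 to compound 4 (within the scatter). Compound 4 is estimated at 3.05, with an expected range of 2.7 to 3.4.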

Compound 4, partition coefficient: 3.11
Compound 4: the middle estimate sits 0.06 log units below what was measured; the range from low to high includes it.
By their numbers in this assay, from the lowest: compound 2; then compound 3; then compounds 1 and 4 (each within the scatter of the next).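

In this assay, within the data shown here, exchanging one ethylphenyl group for the other shows no change at the digits printed from compound 1 to compound 4 (within the scatter) and so gives the first comparison of two ethylphenyl groups. Against the other two groups, 3-ethylphenyl in place of 4-chlorophenyl shows a number 0.35 log units higher from compound 3 to compound 4 (beyond the scatter) and 3-ethylphenyl in place of 4-methoxyphenyl shows a number 1.03 log units higher from compound 2 to compound 4 (beyond the scatter). For these compounds, the two ethylphenyl groups therefore read alike. Still open, from the compounds shown here alone, is how a longer chain such as propyl, an amine or a carboxylic acid would read on this phenyl group. Nothing in hand explains any of these steps.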